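Swapping a Ring Oxygen for Carbon on the Amine

The source may hold more compounds than are shown below. What is called first, only, known or untested is meant among the compounds shown, and "the series" means these compounds.

Compound 1 `c1ccc2c(c1)CN[C@@H](CN(Cc1ccc(CNC3CCOCC3)cc1)[C@H]1CCCc3cccnc31)C2` and compound 2 `CC1(C)CCC(NCc2ccc(CN(C[C@H]3Cc4ccccc4CN3)[C@H]3CCCc4cccnc43)cc2)CC1` share one core, and in a functional assay on cells for antagonist activity at C-X-C chemokine receptor type 4 (Homo sapiens), read by fluorescence and calcium flux, with stated times of 25 min and 90 s (on this read-out higher numbers stand for weaker inhibition and lower numbers for stronger inhibition), compound 1 gives 90.3 nM while compound 2 gives 661 nM. Within the data shown here, the only change between them is 4,4-dimethylcyclohexyl in place of oxan-4-yl on an amine nitrogen, and it brought a 7.3-fold higher number from compound 1 to compound 2 (0.86 log units; beyond the scatter). Compound 3 `C(=C/CN(C[C@H]1Cc2ccccc2CN1)[C@H]1CCCc2cccnc21)\CNC1CCOCC1` has a different core; how its core differs from that of compound 1 is not broken down here, but in this assay compound 3 gives 15.5 nM. Compound 4 `CC1(C)CCC(NC/C=C/CN(C[C@H]2Cc3ccccc3CN2)[C@H]2CCCc3cccnc32)CC1` is made from compound 3 by the same change, (4,4-dimethylcyclohexyl in place of oxan-4-yl on an amine nitrogen), at the same kind of place. Because the earlier step was a 7.3-fold higher number from compound 1 to compound 2 (0.86 log units; beyond the scatter), the step from compound 3 to compound 4 is expected to be similar, about a 6.5-fold higher number from compound 3 to compound 4 (0.81 log units; beyond the scatter). Compound 4 is therefore estimated at 100 nM, most likely between 35 nM and 300 nM.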

Compound 4, half-maximal inhibitory concentration: 64.6 nM
Beside the measured number, compound 4's estimate is 1.5-fold (0.19 log units) above it; the range from low to high includes it.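

Putting 4,4-dimethylcyclohexyl in place of oxan-4-yl on the amine nitrogen gave, in this assay, a 4.2-fold higher number from compound 3 to compound 4 (0.62 log units; beyond the scatter). The number therefore rose on the core of compound 3 as it did on the core of compound 1, and the two steps also agree in size as far as repeat measurements can tell: the same change on two cores in this assay, a 7.3-fold higher number (0.86 log units; beyond the scatter) from compound 1 to compound 2 and a 4.2-fold higher number (0.62 log units; beyond the scatter) from compound 3 to compound 4, 1.8-fold (0.24 log units) apart, within the scatter of two such steps. This shows that the change carried over between these two cores, but two pairs set no rule for other cores and do not explain why the number rises.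

Still open, going by these compounds, is how other groups on this amine nitrogen would behave on either core, such as a plain cyclohexyl without the two methyl groups, or a piperidin-4-yl with a ring nitrogen where oxan-4-yl has its oxygen.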